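The source may hold more compounds than are shown below. What is called first, only, known or untested is meant among the compounds shown, and "the series" means these compounds.

Compound 2, `Cc1ccc(-n2nncc2CN2C(=O)C3(C(C#N)=C(N)Oc4c3c3nc5ccccc5nc3c3ccccc43)c3ccccc32)c(C)c1`, stands at a limit of the assay: in a functional assay on MCF7 cells (Homo sapiens) for antiproliferative activity, read by MTT assay, with a stated time of 48 h (a lower number here means a stronger inhibitor, a higher number a weaker inhibitor), compound 2 gives > 50000 nM, a limit and not a number. Compound 1, `CCOc1ccccc1-n1nncc1CN1C(=O)C2(C(C#N)=C(N)Oc3c2c2nc4ccccc4nc2c2ccccc32)c2ccccc21`, sits at a limit too, giving > 50000 nM in this assay. Among the measured compounds shown here, the step that the two limits leave unreadable from compound 1 to compound 2 is therefore unreadable, and the only evidence is the limit of > 50000 nM in this assay, at which 2 of the 2 values shown sit. Compound 3, `Cc1ccc(Cl)cc1-n1nncc1CN1C(=O)C2(C(C#N)=C(N)Oc3c2c2nc4ccccc4nc2c2ccccc32)c2ccccc21`, differs from compound 2 by 5-chloro-2-methylphenyl in place of 2,4-dimethylphenyl on an aromatic nitrogen. For the measured compounds named here, no measured step bears readably on this change, so the expected step that the limit leaves unreadable from compound 2 to compound 3 is no shift beyond the scatter from a limit. Compound 3 is estimated at 100000 nM, between 30000 nM and 400000 nM, most likely again reported as a limit.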

Compound 3, half-maximal inhibitory concentration: > 50000 nM
Compound 3: no number, only a limit; the forecaster's own chance of this, stated with the estimate: 80%; the middle value is on the limit's open side.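

Among the compounds shown here, compound 3 also gives only a limit, so no step among compound 1, compound 2 and compound 3 can be read: the limit of > 50000 nM in this assay, at which 3 of the 3 values shown sit. Whether any group on the aromatic nitrogen would give a measurable value in this assay stays open with the compounds shown.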